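The source may report more compounds than this note shows. Statements on the series, on what has been measured and on what is new or still open speak of the compounds shown alone.

In a physicochemical assay for solubility, read by HPLC, using the shake flask method, measured as kinetic solubility, with a stated time of 2 h, at pH 7.4 (on this read-out higher numbers stand for higher solubility and lower numbers for lower solubility), compound 1 `Cc1cc(NCc2cccnc2)n2nc(C)c(-c3ccccc3)c2n1` gives 110000 nM. Compound 2 `Cc1cc(NCc2nccn2C)n2nc(C)c(-c3ccccc3)c2n1` gives 26900 nM, a change that reads a 4.1-fold lower number from compound 1 to compound 2 (0.61 log units; beyond the scatter). Compound 3 `Cc1cc(NCc2ncc[nH]2)n2nc(C)c(-c3ccccc3)c2n1` gives only a limit of the assay, < 5000 nM. That reading is the limit of < 5000 nM in this assay, at which 1 of the 3 values shown sits. The steps of an at least 22-fold lower number from compound 1 to compound 3 (1.34 log units; beyond the scatter) and an at least 5.3-fold lower number from compound 2 to compound 3 (0.73 log units; beyond the scatter) therefore place compound 3 at the lowest number shown. Compound 4 `CCN1CCCC1CNc1cc(C)nc2c(-c3ccccc3)c(C)nn12` differs from compound 3 in one place: 1-ethylpyrrolidin-2-yl in place of 1H-imidazol-2-yl on a saturated chain carbon bound to a nitrogen on an aromatic ring. Of the measured steps, the one that bears most directly on this change is an at least 5.3-fold lower number from compound 2 to compound 3 (0.73 log units; beyond the scatter), in which a hydrogen-bond donor came in and the number fell; here the donor leaves again. An upward step beyond the scatter is therefore expected, namely an at least 20-fold higher number from compound 3 to compound 4 (1.30 log units; beyond the scatter). Compound 4 is estimated at 100000 nM, in a range from 20000 nM to 500000 nM.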

Compound 4, solubility: 172000 nM
Beside the measured number, compound 4's estimate is 1.7-fold (0.24 log units) below it; the measured number falls inside the stated range.
By their numbers in this assay, from the lowest: compound 2; then compounds 1 and 4 (each within the scatter of the next). At a limit, below all of these: compound 3.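

Until now only aromatic rings had stood on this saturated chain carbon, and the non-aromatic 1-ethylpyrrolidin-2-yl shows that such a ring can stand there too, with a 6.4-fold higher number from compound 2 to compound 4 (0.81 log units; beyond the scatter) in this assay. Against the pyridin-3-yl of compound 1 there is a 1.6-fold higher number from compound 1 to compound 4 (0.19 log units; within the scatter), while the imidazole without the methyl gives an at least 34-fold higher number from compound 3 to compound 4 (1.53 log units; beyond the scatter). Compound 3 is held at a limit, so that last step is a bound only: the limit of < 5000 nM in this assay, at which 1 of the 4 values shown sits.

The compounds shown leave open whether the ethyl group or the ring itself carries the step. A pyrrolidin-2-yl without the ethyl, or an open-chain amine, would separate the two.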